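The source may hold more compounds than are shown below. What is called first, only, known or untested is meant among the compounds shown, and "the series" means these compounds.

Measured so far in an assay on CHO cells for displacement of a labelled ligand from adenosine receptor A1 (Homo sapiens), read by scintillation counting, with a stated time of 120 min, tested at 1 uM; on this read-out lower numbers stand for less inhibition and higher numbers for more inhibition at the one concentration tested (going by the name of the read-out):
Compound 1, `Cc1nc2sc(-c3ccccc3)nc2c(=O)[nH]1`, gives 11%.
Compound 2, `Cc1cccc(-c2nc3c(=O)[nH]c(C)nc3s2)c1`, gives 1%.
Compound 3, `Cc1nc2sc(-c3cccc(F)c3)nc2c(=O)[nH]1`, gives 1%.

On these numbers compound 3 matches compound 2 at the digits reported, and its gap to compound 1 also lies within the usual scatter, so the three measured compounds cannot be told apart by this read-out. Compound 4, `Cc1nc2sc(-c3cccc(C(F)(F)F)c3)nc2c(=O)[nH]1`, has not yet been measured. It differs from compound 3 by trifluoromethyl in place of fluoro on an aromatic carbon.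

Among the measured compounds shown here, the steps that bear on this change are those at the same aromatic carbon: a number 10 percentage points lower from compound 1 to compound 3 (within the scatter) and no change at the digits printed from compound 2 to compound 3 (within the scatter), with a number 10 percentage points lower from compound 1 to compound 2 (within the scatter) completing the set. None of them leaves the scatter, so swapping one small group for another at this position has so far not moved the read-out in either direction. There is no ground in the data for expecting a step beyond the scatter here either.

Compound 4 is therefore expected to give 3%, within a range of -8% to 15%, which means an expected step of a number 2 percentage points higher from compound 3 to compound 4 (within the scatter).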

Compound 4, a percentage reported as inhibition, at one concentration (the size of the read-out at that concentration, not a potency): 1%
For compound 4 the middle estimate is 2 percentage points above the measured one; the measured number falls inside the stated range.
By their numbers in this assay, from the lowest: compounds 2, 3, 4 and 1 (each within the scatter of the next).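

In this assay, trifluoromethyl, with 4 heavy atoms against 1 for fluoro, extends the earlier finding to a bigger group on this aromatic carbon: the swap for fluoro shows no change at the digits printed from compound 3 to compound 4 (within the scatter), and the swap for methyl shows no change at the digits printed from compound 2 to compound 4 (within the scatter). Set against hydrogen, the new group shows a number 10 percentage points lower from compound 1 to compound 4 (within the scatter), so all three groups placed here remain within the scatter of the parent compound 1. No measured evidence is available to explain this flat result.

As far as these compounds go, it remains open whether an amine, a carboxylic acid or a longer chain on this aromatic carbon would move the number beyond the scatter. It is also open whether a change elsewhere on the shared core would do so, and a reading at one concentration gives no potency for any of these compounds.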